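A few compounds are considered here, and "the series" means these few. Any claim that something is new, unique, unknown or untested is made for them only; others in the source may bear on it.

Measured so far:
compound 1, `Cn1ncc2c(-c3ccc(F)cc3)cc(NNC(=O)Nc3cc(Cl)nc(OCCF)c3)nc21` — 2790 nM
compound 2, `CCCCOc1cc(NC(=O)NNc2cc(-c3ccc(OC)cc3)c3cnn(C)c3n2)cc(Cl)n1` — 4150 nM

Both compounds have been characterised in an assay on isolated protein for binding affinity to sphingosine 1-phosphate receptor 2 (Homo sapiens), read by surface plasmon resonance; on this read-out lower numbers stand for tighter binding and higher numbers for weaker binding. Compound 1 gives 2790 nM; compound 2 gives 4150 nM. The gap between the two sits within the scatter of repeated measurements, so compound 1 cannot be set apart from compound 2 on this read-out, and the pair gives no direction for the series yet.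

The next compound, compound 3, `Cn1ncc2c(-c3ccc(F)cc3)cc(NNC(=O)Nc3cc(F)cc(F)c3)nc21`, keeps the shared core of compound 1 and changes the aryl group on the urea: 3,5-difluorophenyl in place of 2-chloro-6-(2-fluoroethoxy)pyridin-4-yl on an amide-type nitrogen. Within the data shown here, no step between two measured compounds covers a change of this kind, so there is no measured precedent to lean on. With compound 1 at 2790 nM the expectation is a modest step, more likely toward weaker binding than tighter, but not clearly beyond the scatter. Compound 3 is therefore estimated at 4000 nM in this assay, with a range from 1500 nM to 12000 nM; the estimated step is a 1.4-fold higher number from compound 1 to compound 3 (0.16 log units; within the scatter).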

Compound 3, dissociation constant: 3980 nM
Beside the measured number, compound 3's estimate is 1.0-fold (0.00 log units) above it; low and high end bracket the measured number.
By their numbers in this assay, from the lowest: compounds 1, 3 and 2 (each within the scatter of the next).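

In this assay, among these compounds, 3,5-difluorophenyl in place of 2-chloro-6-(2-fluoroethoxy)pyridin-4-yl on the amide-type nitrogen gives a 1.4-fold higher number from compound 1 to compound 3 (0.15 log units; within the scatter), the first step that can be read at this position. For this one pair, an aryl group of 11 heavy atoms with 2 hydrogen-bond acceptors and one of 8 heavy atoms with 0 hydrogen-bond acceptors cannot be told apart on this read-out, so the chlorine, the ring nitrogen and the 2-fluoroethoxy chain are not shown as a group to be essential to the binding seen with compound 1. No supporting data bear on why the pair reads this way.

Still open, as far as these compounds go, is whether any aryl group on this urea nitrogen can move the number beyond the scatter, for example one carrying a carboxylic acid, a primary amine or a longer alkoxy chain. Compound 2 differs from compound 1 in more than one place, so the aryl group on the shared core and the butoxy chain remain unseparated as single changes.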